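From compound 2 to compound 3: butyl replaces five-membered ring

A few compounds are considered here, and "the series" means these few. Any claim that something is new, unique, unknown or untested is made for them only; others in the source may bear on it.

Two compounds have numbers in a functional assay (B cells) with Mus musculus as the target; on this read-out lower numbers stand for an effect already at smaller amounts and higher numbers for an effect only at larger amounts of compound. Compound 1 `[N-]=[N+]=NCC(O)Cn1c(=O)n(C2OC(CO)[C@@H](O)[C@H]2O)c2nc(N)nc(O)c21` gives 39 uM. Compound 2 `C=CCn1c(=O)n(C2CCC(CO)C2)c2nc(N)nc(O)c21` gives 226 uM, the higher of the two numbers; compound 1 sits below it by a gap beyond the scatter. Compound 3 `C=CCn1c(=O)n(CCCC)c2nc(N)nc(O)c21` has not been measured. It differs from compound 2 in one place: a group of 4 heavy atoms (4 carbon; no ring) in place of a group of 7 heavy atoms (6 carbon, 1 oxygen; one five-membered non-aromatic ring of carbon only), on an aromatic nitrogen. Among the compounds with values here, no measured pair shows this change, so its size cannot be read from the numbers at hand. The step of a 1.8-fold higher number from compound 2 to compound 3 (0.25 log units; within the scatter) is expected to be small and toward higher numbers, possibly within the scatter. Compound 3 is estimated at 400 uM, with a range from 150 uM to 1000 uM.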

Compound 3, concentration for half-maximal effect: 2 uM
Compound 3: the middle estimate sits 200-fold (2.30 log units) above what was measured; the whole stated range lies above it.
By their numbers in this assay, from the lowest: compound 3; then compound 1; then compound 2.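

In this assay the group on this aromatic nitrogen proves a strong lever, with a 110-fold lower number from compound 2 to compound 3 (2.05 log units; beyond the scatter) as butyl enters. A group with no ring and with no hydrogen-bond donor or acceptor is therefore enough here for an effect at low amounts, and the five-membered ring with its oxygen is not required. Nothing at hand accounts for the size of this step. Still open, going by these compounds, is whether the chain or the loss of the ring drives the step. A longer chain such as hexyl, or a butyl ending in a hydroxyl, would help separate the two.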